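The source may report more compounds than this note shows. Statements on the series, on what has been measured and on what is new or still open speak of the compounds shown alone.

Going by the values given here, in an assay on HT-29 cells with Methylated-DNA--protein-cysteine methyltransferase (Homo sapiens) as the target, with a stated time of 30 min (on this read-out higher numbers stand for an effect only at larger amounts of compound and lower numbers for an effect already at smaller amounts), compound 2 `Oc1nc(OCc2ccccc2)c2[nH]cnc2n1` gives 60 uM, the highest of the three numbers measured so far. Compound 1 `Nc1nc(OCc2ccccc2)c2[nH]c(N)nc2n1` gives 0.7 uM, and compound 3 `Oc1nc(OCc2ccccc2)c2[nH]c(O)nc2n1` gives 25 uM. Among the compounds with values here, the one single-change step measured, a 2.4-fold lower number from compound 2 to compound 3 (0.38 log units; beyond the scatter), touches the same position that changes now. Compound 4 `Fc1nc(OCc2ccccc2)c2[nH]cnc2n1` differs from compound 2 by fluoro in place of hydroxy on an aromatic carbon. Within the data shown here, no measured step covers a fluoro at this place; the hydroxy-for-hydrogen step gave only a modest shift, while compound 1 sits far lower on this read-out. Compound 4 is therefore expected to land near compound 2, with an estimate of 40 uM and a range from 10 uM to 150 uM. The expected step, a 1.5-fold lower number from compound 2 to compound 4 (0.18 log units; within the scatter), should stay within the scatter.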

Compound 4, concentration for half-maximal effect: 48 uM
For compound 4 the middle estimate is 1.2-fold (0.08 log units) below the measured one, within the range that was stated.
By their numbers in this assay, from the lowest: compound 1; then compounds 3, 4 and 2 (each within the scatter of the next, the first and the last beyond it).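

In this assay, replacing the hydroxy with fluoro gives a 1.3-fold lower number from compound 2 to compound 4 (0.10 log units; within the scatter) and so leaves the number effectively unchanged at this place. The hydroxy counts a hydrogen-bond donor and acceptor and the fluoro counts neither, so for this pair those counts make no difference beyond the scatter. Nothing available here gives a reason for this.

As far as these compounds go, whether a methoxy or a chloro at this place would also leave the number unchanged stays open. From the compounds shown here alone, the effect of an amine here on its own also stays open, as compound 1 differs from compound 2 in a second place too.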